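A few compounds are considered here, and "the series" means these few. Any claim that something is new, unique, unknown or untested is made for them only; others in the source may bear on it.

Values in a functional assay on HCT-116 cells (Homo sapiens) for antiproliferative activity, read by sulforhodamine B assay, with a stated time of 4 days; a higher number here means a weaker inhibitor of growth, a lower number a stronger inhibitor of growth:
compound 1 `COc1cc(Cl)c(-c2nc(SCC(=O)NC(C)C)nc3[nH]cc(C#N)c23)cc1O`: 238 nM
compound 2 `COc1cc(Cl)c(-c2nc(SCC(=O)NC(C)(C)C)nc3[nH]cc(C#N)c23)cc1O`: 117 nM
compound 3 `COc1cc(Cl)c(-c2nc(SCC(=O)NC(C)(C)C)nc3[nH]cc(C#N)c23)cc1OC`: 50 nM

Compound 3 has the lowest of the three numbers in this assay, at 50 nM, and compound 2 lies nearest to it. Compound 4 `COc1cc(Cl)c(-c2nc(SCC(=O)NC(C)C)nc3[nH]cc(C#N)c23)cc1OC` differs from compound 3 by hydrogen in place of methyl on a saturated chain carbon bound to an amide-type nitrogen and two saturated chain carbons, that is, tert-butyl to isopropyl: hydrogen in place of methyl on a saturated chain carbon bound to an amide-type nitrogen and two saturated chain carbons.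

Going by the values given here, the closest precedent is the reverse change, isopropyl to tert-butyl, seen as a 2.0-fold lower number from compound 1 to compound 2 (0.31 log units; beyond the scatter). That modest step was measured with hydrogen, not methyl, on the aromatic ring oxygen. The oxygen change itself gave a 2.3-fold lower number from compound 2 to compound 3 (0.37 log units; beyond the scatter), also modest, and it links compound 1 to compound 4 in the same way. Together these point to a higher number for compound 4, with a modest step of similar size to a 2.0-fold lower number from compound 1 to compound 2 (0.31 log units; beyond the scatter).

The expected step is a 2.0-fold higher number from compound 3 to compound 4 (0.30 log units; within the scatter). For compound 4 the estimated value is 100 nM, with an expected range of 55 nM to 190 nM.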

Compound 4, concentration for 50% growth inhibition: 81 nM
Compound 4: the middle estimate sits 1.2-fold (0.09 log units) above what was measured; low and high end bracket the measured number.
By their numbers in this assay, from the lowest: compounds 3, 4 and 2 (each within the scatter of the next, the first and the last beyond it); then compound 1.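

In this assay, tert-butyl to isopropyl with methyl on the aromatic ring oxygen gives a 1.6-fold higher number from compound 3 to compound 4 (0.21 log units; within the scatter), so on this core the step alone cannot be told from repeat scatter. Read in reverse, isopropyl to tert-butyl now has a second instance, and the two instances agree: the same change on two cores in this assay, a 2.0-fold lower number (0.31 log units; beyond the scatter) from compound 1 to compound 2 and a 1.6-fold lower number (0.21 log units; within the scatter) from compound 4 to compound 3, 1.3-fold (0.10 log units) apart, within the scatter of two such steps. The methyl in place of hydrogen on the aromatic ring oxygen also gains a second instance, a 2.9-fold lower number from compound 1 to compound 4 (0.47 log units; beyond the scatter), and it holds with isopropyl as with tert-butyl: the same change on two cores in this assay, a 2.3-fold lower number (0.37 log units; beyond the scatter) from compound 2 to compound 3 and a 2.9-fold lower number (0.47 log units; beyond the scatter) from compound 1 to compound 4, 1.3-fold (0.10 log units) apart, within the scatter of two such steps.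

The compounds shown cover only two groups in this place and only hydrogen or methyl on the ring oxygen. As far as these compounds go, how this assay responds to cyclopropyl or a longer chain such as n-butyl in place of tert-butyl, or to ethyl in place of methyl on the oxygen, remains open.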